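From 3,4-Dihydroxyphenyl to Phenyl in a Glycoside Ester

The source may hold more compounds than are shown below. What is called first, only, known or untested is meant among the compounds shown, and "the series" means these compounds.

Among the compounds with values here, in a functional assay on K562 cells (Homo sapiens) for antiproliferative activity, read by MTT assay, with a stated time of 72 h (on this read-out higher numbers stand for weaker inhibition and lower numbers for stronger inhibition), compound 2 `C/C=C1/[C@H](O[C@@H]2O[C@H](CO)[C@@H](O)[C@H](O)[C@H]2O)OC=C(C(=O)OC)[C@H]1CC(=O)OCCc1ccc(O)c(O)c1` gives 64700 nM, the highest of the three numbers measured so far and beyond the scatter from both of the others. Compound 3 `C/C=C1/[C@H](O[C@@H]2O[C@H](COC(C)=O)[C@@H](OC(C)=O)[C@H](OC(C)=O)[C@H]2OC(C)=O)OC=C(C(=O)OC)[C@H]1CC(=O)OCCC` gives 8500 nM, and compound 1 `C/C=C1/[C@H](O[C@@H]2O[C@H](CO)[C@@H](O)[C@H](O)[C@H]2O)OC=C(C(=O)OC)[C@H]1CC(=O)OCCCCCCCCCCCCCCC` gives 700 nM. Within the data shown here, neither of these carries 3,4-dihydroxyphenyl, yet each also differs from compound 2 elsewhere in its structure, so no measured pair isolates that group.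

Compound 4 `C/C=C1/[C@H](O[C@@H]2O[C@H](CO)[C@@H](O)[C@H](O)[C@H]2O)OC=C(C(=O)OC)[C@H]1CC(=O)OCCc1ccccc1` has not yet been measured. It has phenyl in place of 3,4-dihydroxyphenyl on a saturated chain carbon, two bonds along the chain from an oxygen next to a carbonyl group. Since compound 1 at 700 nM and compound 3 at 8500 nM both lie lower, the change is expected to move the number down, though only moderately and with much uncertainty. In this assay the expected step is a 3.2-fold lower number from compound 2 to compound 4 (0.51 log units; beyond the scatter). For compound 4 the estimated value is 20000 nM, with an expected range of 6000 nM to 65000 nM.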

Compound 4, half-maximal inhibitory concentration: 20000 nM
Compound 4: middle estimate and measured number agree at the digits printed; the range from low to high includes it.
By their numbers in this assay, from the lowest: compound 1; then compound 3; then compound 4; then compound 2.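

Within the data shown here, compound 2 and compound 4 are the first pair here that differ in one place only, so the change can now be read on its own. In this assay, phenyl in place of 3,4-dihydroxyphenyl, on a saturated chain carbon, two bonds along the chain from an oxygen next to a carbonyl group, gives a 3.2-fold lower number from compound 2 to compound 4 (0.51 log units; beyond the scatter), a modest step that lies beyond the scatter. No measurement shown here explains this step.

The compounds shown leave open how other groups on the phenyl ring, such as a methoxy group, a fluorine atom or a carboxylic acid, would compare at this position. They also leave open whether the same step would appear with the acetate esters that compound 3 carries.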